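The source may report more compounds than this note shows. Statements on the series, on what has been measured and on what is new or still open speak of the compounds shown alone.

Three compounds share one core and differ only in the aromatic group on the amide nitrogen. Compound 3 `Cc1occc1-c1nnc(SCC(=O)Nc2cccc(Cl)c2)n1Cc1ccco1` gives 63.1 nM in a functional assay on CHO cells for antagonist activity at Orexin receptor type 2 (Homo sapiens), read by FLIPR and calcium flux; a lower number here means a stronger inhibitor, a higher number a weaker inhibitor. Compound 2 `Cc1ccc(NC(=O)CSc2nnc(-c3ccoc3C)n2Cc2ccco2)cc1` gives 39.8 nM, and compound 1 `Cc1ccc(C)c(NC(=O)CSc2nnc(-c3ccoc3C)n2Cc2ccco2)c1` gives 398 nM. Compound 3 thus has the second highest of the three numbers: it sits close to compound 2, as a 1.6-fold higher number from compound 2 to compound 3 (0.20 log units; within the scatter) shows, and far from compound 1, as a 6.3-fold lower number from compound 1 to compound 3 (0.80 log units; beyond the scatter) shows.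

Compound 4 `COc1ccccc1NC(=O)CSc1nnc(-c2ccoc2C)n1Cc1ccco1` carries the change (2-methoxyphenyl in place of 3-chlorophenyl on an amide-type nitrogen). The measured steps that bear on this are the swaps of the same aromatic group: a 10-fold lower number from compound 1 to compound 2 (1.00 log units; beyond the scatter), a 6.3-fold lower number from compound 1 to compound 3 (0.80 log units; beyond the scatter) and a 1.6-fold higher number from compound 2 to compound 3 (0.20 log units; within the scatter). They show that this group can move the number by a modest amount or not beyond the scatter. For the measured compounds named here, no measured step introduces a methoxy group, so the direction is uncertain. A small rise is expected for compound 4, of about a 2.4-fold higher number from compound 3 to compound 4 (0.38 log units; beyond the scatter), giving an estimate of 150 nM with a range from 40 nM to 600 nM.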

Compound 4, inhibition constant: 501 nM
The estimate for compound 4 lay 3.3-fold (0.52 log units) below the measured number; measured number inside the range.
By their numbers in this assay, from the lowest: compounds 2 and 3 (each within the scatter of the next); then compounds 1 and 4 (each within the scatter of the next).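

The amide-nitrogen group turns out to split these four compounds into two clear levels, and a methoxy group does not escape that split. The 2-methoxyphenyl of compound 4 stands well apart from the 3-chlorophenyl of compound 3 (a 7.9-fold higher number from compound 3 to compound 4 (0.90 log units; beyond the scatter)) and further still from the 4-methylphenyl of compound 2 (a 13-fold higher number from compound 2 to compound 4 (1.10 log units; beyond the scatter)), yet it matches the 2,5-dimethylphenyl of compound 1 (a 1.3-fold higher number from compound 1 to compound 4 (0.10 log units; within the scatter)). So the two groups whose names carry a substituent at position 2 share the high level and no compound shown goes against this, though four compounds make thin support for a pattern.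

As far as these compounds go, whether 4-methoxyphenyl would return to the level of compound 2 and compound 3 stays open, as does what an amine or a carboxylic acid on the phenyl ring would give. No measurement shown accounts for the split between these two levels.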